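From Cyclohexyl to Benzyl on the Shared Core

This account rests on a few compounds, and the source may have more. Where it says the series, first, only, none or still open, it means among the compounds named here.

Three compounds built on one shared core were compared in an assay on K562 cells for displacement of a labelled ligand from Equilibrative nucleoside transporter 1 (Homo sapiens), read by flow cytometry, with a stated time of 45 min; on this read-out higher numbers stand for weaker inhibition and lower numbers for stronger inhibition. Compound 1 `CCCNc1nc(SCc2ccc([N+](=O)[O-])cc2)c2ncn([C@@H]3O[C@H](CO)[C@@H](O)[C@H]3O)c2n1` gives 193 nM. Compound 2 `O=[N+]([O-])c1ccc(CSc2nc(NC3CCC3)nc3c2ncn3[C@@H]2O[C@H](CO)[C@@H](O)[C@H]2O)cc1` gives 33 nM. Compound 3 `O=[N+]([O-])c1ccc(CSc2nc(NC3CCCCC3)nc3c2ncn3[C@@H]2O[C@H](CO)[C@@H](O)[C@H]2O)cc1` gives 400 nM, the highest of the three numbers, so it is the weakest inhibitor among them. Swapping propyl for cyclobutyl gave a 5.8-fold lower number from compound 1 to compound 2 (0.77 log units; beyond the scatter); swapping propyl for cyclohexyl gave a 2.1-fold higher number from compound 1 to compound 3 (0.32 log units; beyond the scatter); and a 12-fold higher number from compound 2 to compound 3 (1.08 log units; beyond the scatter) shows how much the number rose on going from the smaller ring to the larger one. Compound 4 `O=[N+]([O-])c1ccc(CSc2nc(NCc3ccccc3)nc3c2ncn3[C@@H]2O[C@H](CO)[C@@H](O)[C@H]2O)cc1` differs from compound 3 by benzyl in place of cyclohexyl on a nitrogen on an aromatic ring. Among the compounds with values here, none of the measured steps exchanges a saturated ring for an aromatic one, so they show only that the group on this nitrogen can move the number considerably in either direction. Without a closer guide, compound 4 is expected to give 200 nM, within 60 nM to 700 nM, which corresponds to an expected step of a 2.0-fold lower number from compound 3 to compound 4 (0.30 log units; within the scatter).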

Compound 4, inhibition constant: 247 nM
The estimate for compound 4 lay 1.2-fold (0.09 log units) below the measured number; the range from low to high includes it.
By their numbers in this assay, from the lowest: compound 2; then compounds 1, 4 and 3 (each within the scatter of the next, the first and the last beyond it).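

In this assay the exchange of cyclohexyl for benzyl brings a 1.6-fold lower number from compound 3 to compound 4 (0.21 log units; within the scatter) so on this nitrogen the six-membered aromatic ring of benzyl and the six-membered non-aromatic ring of cyclohexyl cannot be told apart by this pair. Benzyl also stays level with propyl, with a 1.3-fold higher number from compound 1 to compound 4 (0.11 log units; within the scatter) while cyclobutyl alone stands clear of the other groups, with a 7.5-fold higher number from compound 2 to compound 4 (0.87 log units; beyond the scatter) making the small ring the one distinct gain among the four. Nothing shown gives a reason for these steps.

From the compounds shown here alone, whether that gain follows ring size remains open, and cyclopropyl and cyclopentyl on the same nitrogen would fill around cyclobutyl. A phenyl placed directly on the nitrogen, or a longer phenylethyl chain, would separate the aromatic ring's contribution from that of the link holding it.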